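From Methoxycarbonyl to Carbamoyl: Compound 1 to Compound 4

The source may hold more compounds than are shown below. What is called first, only, known or untested is meant among the compounds shown, and "the series" means these compounds.

Of the compounds shown here, three have been measured in a functional assay on the whole organism for inhibition, with Rattus norvegicus as the target, at a dose of 3 mg/kg; on this read-out lower numbers stand for less inhibition and higher numbers for more inhibition at the one dose given (going by the name of the read-out). Compound 1 `CCCCn1nc(C)c(C(=O)OC)c1Cc1ccc(-c2ccccc2-c2nn[nH]n2)cc1` gives 52.5%. Compound 2 `Cc1nn(-c2ccccc2)c(Cc2ccc(-c3ccccc3-c3nn[nH]n3)cc2)c1C(=O)O` gives 57.4%, and compound 3 `CCCCn1nc(-c2ccccc2)c(C(=O)O)c1Cc1ccc(-c2ccccc2-c2nn[nH]n2)cc1` gives 44.1%. On these numbers compound 1 stands second highest of the three; its nearest neighbour is compound 2, whose number lies higher by an amount within the scatter, and the gap to compound 3 is likewise within the scatter, so no order among the three can be asserted.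

Compound 4 `CCCCn1nc(C)c(C(N)=O)c1Cc1ccc(-c2ccccc2-c2nn[nH]n2)cc1` has not yet been measured. It differs from compound 1 in one place: amino in place of methoxy on a carbonyl carbon. Cut one bond further out, the change reads methoxycarbonyl to carbamoyl. Going by the values given here, no step between measured compounds is available to gauge such a change, since compounds 2 and 3 differ from compound 1 in more than one place. The three measured values all lie within the scatter of one another, which gives no indication of a large swing in either direction. The step from compound 1 to compound 4 in this assay is therefore expected to be small, a number 2.5 percentage points lower from compound 1 to compound 4 (within the scatter), with no direction beyond the scatter. Compound 4 is estimated at 50%, within a range from 30% to 70%.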

Compound 4, a percentage reported as inhibition, in the whole organism at one dose (the size of the read-out at that dose, not a potency): 74.9%
The estimate for compound 4 lay 24.9 percentage points below the measured number; the measured number lies above the stated range.
By their numbers in this assay, from the lowest: compounds 3, 1 and 2 (each within the scatter of the next, the first and the last beyond it); then compound 4.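

In this assay, the group on this carbonyl carbon proves able to shift the read-out: amino in place of methoxy gives a number 22.4 percentage points higher from compound 1 to compound 4 (beyond the scatter), a step beyond the usual scatter. The earlier compounds shown here could not show this, as they differ from one another in more than one place and offered no single change to read at this or any other position. The two groups differ in size and in their counts of hydrogen-bond donors and acceptors, but nothing measured here ties the step to any of these differences or to any other property of the groups.

The compounds shown leave open whether the step depends on the unsubstituted amino group, since a methylamino or dimethylamino group on the same carbonyl carbon would separate the presence of the amide hydrogen from the simple loss of methoxy. They also leave open whether the same exchange would give a step of similar size with a chain other than the butyl and methyl groups of compound 1 and compound 4, or at a dose other than the one used here.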